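Reversing a double bond geometry in a cationic bicyclic series

This account rests on a few compounds, and the source may have more. Where it says the series, first, only, none or still open, it means among the compounds named here.

Measured so far:
compound 1 `CCCCCCCC/C=C\c1c(C)cc(C)nc1CCCOC` gives > 30 uM
compound 2 `CCCCCCCC/C=C\c1c(C)c(/C=C/CCCCCCCC)c2[n+](c1C)CCC2` gives 0.5 uM
compound 3 `CCCCCCCC/C=C\c1c(C)c(/C=C\CCCCCCCC)c2[n+](c1C)CCC2` gives 1.1 uM

The read-out throughout is a functional assay on PC-3 cells (Homo sapiens) for antiproliferative activity, read by WST assay, with a stated time of 72 h; on this read-out lower numbers stand for an effect already at smaller amounts and higher numbers for an effect only at larger amounts of compound. Compound 1 reports only a limit, > 30 uM, and not a number. Among the two numbers, compound 3 stands highest; its nearest neighbour is compound 2, and the step of a 2.2-fold higher number from compound 2 to compound 3 (0.34 log units; beyond the scatter) rests on (the fact that compounds 2 and 3 differ only in the configuration as drawn).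

Compound 4 `CCCCCCCC/C=C\c1c(C)c(/C=C/CCCCCCCC)c(C)[n+]2c1CCC2` is now to be measured. Compared with compound 3 it shows (the two compounds have the same atoms and bonds and differ only in configuration as drawn: 1 of 2 stereo elements differ; a double bond is drawn Z in compound 3 and E in compound 4). Within the data shown here, this is exactly the change of the only measured step, run backwards, so the step of a 2.2-fold higher number from compound 2 to compound 3 (0.34 log units; beyond the scatter) is the one piece of evidence that bears on it, and a modest reversal in the opposite direction is the expectation here. Compound 4 is therefore estimated at 0.5 uM, with a range from 0.25 uM to 1.1 uM, the expected step being a 2.2-fold lower number from compound 3 to compound 4 (0.34 log units; beyond the scatter).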

Compound 4, concentration for half-maximal effect: 0.7 uM
Compound 4: the middle estimate sits 1.4-fold (0.15 log units) below what was measured, and the stated range covers the measured number.
By their numbers in this assay, from the lowest: compounds 2, 4 and 3 (each within the scatter of the next, the first and the last beyond it). At a limit, above all of these: compound 1.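

In this assay, the change from Z to E at one double bond gives a 1.6-fold lower number from compound 3 to compound 4 (0.20 log units; within the scatter), so this reversal does not repeat the clear separation seen for the earlier pair. Changing the drawn geometry at both double bonds gives a 1.4-fold higher number from compound 2 to compound 4 (0.15 log units; within the scatter), which also stays inside the usual variation. Geometry is the only difference within each pair: the fact that compounds 3 and 4 differ only in the configuration as drawn

The compounds shown leave open what happens when a saturated alkyl chain replaces either alkenyl chain. They also leave open the effect of a terminal carboxylic acid on that chain.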